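This account rests on a few compounds, and the source may have more. Where it says the series, first, only, none or still open, it means among the compounds named here.

Measured in an ADME assay on MT4 cells (Homo sapiens) for cytotoxicity, read by MTT assay, with a stated time of 4 days; on this read-out higher numbers stand for lower toxicity in this test and lower numbers for higher toxicity in this test:
compound 1 `N#Cc1ccc(Nc2nc(Oc3ccccc3Cl)c3ccccc3n2)cc1` gives 38000 nM
compound 2 `N#Cc1ccc(Nc2nc(Oc3ccc(Cl)cc3Cl)c3ccccc3n2)cc1` gives 32000 nM
compound 3 `Cc1cc(C#N)cc(C)c1Oc1nc(Nc2ccc(C#N)cc2)nc2ccccc12` gives 203000 nM

Compound 3 stands highest of the three numbers in this assay. The steps that reach it are a 5.3-fold higher number from compound 1 to compound 3 (0.73 log units; beyond the scatter) and a 6.3-fold higher number from compound 2 to compound 3 (0.80 log units; beyond the scatter), both beyond the scatter and both modest, and both exchange the whole group on the oxygen; the step of a 1.2-fold lower number from compound 1 to compound 2 (0.07 log units; within the scatter) lies within the scatter. Compound 4 `Cc1cc(C)c(Oc2nc(Nc3ccc(C#N)cc3)nc3ccccc23)c(C)c1` differs from compound 3 by methyl in place of cyano on an aromatic carbon. Going by the values given here, no measured pair isolates the cyano group on this ring, so the two steps into compound 3 bear on it only loosely: they show that changing the group on the oxygen can move this assay by a modest amount, but they do not show which part of that group carries the effect. The expected step is therefore small, and is estimated as a 1.7-fold lower number from compound 3 to compound 4 (0.23 log units; within the scatter), in the downward direction, within or just beyond the scatter. For compound 4 the expected value in this assay is 120000 nM, with a range of 45000 nM to 300000 nM.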

Compound 4, half-maximal cytotoxic concentration: > 34000 nM
Compound 4: no number, only a limit; the forecaster's own chance of this, stated with the estimate: 20%; the middle value does not contradict the limit.
By their numbers in this assay, from the lowest: compounds 2 and 1 (each within the scatter of the next); then compound 3.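

In this assay the reading for compound 4 is a limit and not a number: the limit of > 34000 nM in this assay, at which 1 of the 4 values shown sits. Set against compound 2, it supports only a floor, an at least 1.0-fold higher number from compound 2 to compound 4 (0.02 log units; that floor lies within the scatter), and the steps to compound 4 from compound 3 and compound 1 cannot be read. For methyl in place of cyano on this aromatic carbon, para to a large group, the result therefore gives no size, and it does not show whether the cyano group carries the higher number of compound 3.

Still open, from the compounds shown here alone, are where compound 4 truly lies relative to compound 3 and whether the cyano group or the two methyl groups on this ring account for the higher number of compound 3. Also open, going by these compounds, is how an amine or a carboxylic acid on this same carbon would read in this assay.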